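The source may hold more compounds than are shown below. What is called first, only, known or untested is meant among the compounds shown, and "the series" means these compounds.

Compound 1 `CC(C)=CCC/C(C)=C/CC1Cc2c(OCc3ccccc3)cc(=O)n(CCCO)c2CC1(C)C` gives 1.5% in a functional assay on PANC-1 cells (Homo sapiens) for inhibition, read by MTT assay, with a stated time of 24 h, tested at 10 uM; on this read-out lower numbers stand for less inhibition and higher numbers for more inhibition at the one concentration tested (going by the name of the read-out); compound 2 `CC(C)=CCC/C(C)=C/CC1Cc2c(OC(=O)Nc3cccc(F)c3)cc(=O)n(CCCO)c2CC1(C)C` gives 0%.

Compound 2 stands lowest of the two numbers, with compound 1 nearest; the step of a number 1.5 percentage points lower from compound 1 to compound 2 (within the scatter) is within the scatter. Compound 3 `CC(C)=CCC/C(C)=C/CC1Cc2c(OC(=O)Nc3cccc(C(F)(F)F)c3)cc(=O)n(CCCO)c2CC1(C)C` is not yet measured. It differs from compound 2 by trifluoromethyl in place of fluoro on an aromatic carbon, on an aromatic carbon meta to a large group. Going by the values given here, no measured step bears directly on this change; the only known step, from a benzyl to a carbamoyl group, stayed within the scatter, and both measured values sit near zero. The expected step of a number 2 percentage points higher from compound 2 to compound 3 (within the scatter) is therefore none beyond the scatter. Compound 3 is estimated at 2%, range 0% to 12%.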

Compound 3, a percentage reported as inhibition, at one concentration (the size of the read-out at that concentration, not a potency): 6.7%
Compound 3: the middle estimate sits 4.7 percentage points below what was measured; the measured number falls inside the stated range.
By their numbers in this assay, from the lowest: compounds 2, 1 and 3 (each within the scatter of the next).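

In this assay, going by these compounds alone, the change from 3-fluorophenyl to 3-(trifluoromethyl)phenyl is the first one made on this aromatic ring itself, and it gives a number 6.7 percentage points higher from compound 2 to compound 3 (within the scatter). At this aromatic carbon, then, trifluoromethyl with its 4 heavy atoms and fluoro with its 1 are not separated by this read-out at the one concentration tested. No measurement here bears on why this step has the size it does. From the compounds shown here alone, whether an amine or a carboxylic acid on this aromatic carbon would give a step beyond the scatter remains open.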